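The source may report more compounds than this note shows. Statements on the series, on what has been measured and on what is new or still open speak of the compounds shown alone.

Measured compounds in an assay on THP-1 cells for displacement of a labelled ligand from C-C chemokine receptor type 1 (Homo sapiens); on this read-out lower numbers stand for stronger inhibition and higher numbers for weaker inhibition:

- compound 1, `CC(C)CCC(=O)N[C@@H](C(=O)N1CCC(c2ccc(Cl)cc2)CC1)C(C)C`, 26 nM
- compound 2, `Cc1ccc(C(=O)N[C@@H](C(=O)N2CCC(c3ccc(Cl)cc3)CC2)C(C)C)cc1`, 25 nM
- compound 3, `CC(C)C(NC(=O)c1ccccc1)C(=O)N1CCC(c2ccc(F)cc2)CC1`, 423 nM

Compound 2 stands at the lowest of the three numbers in this assay, but compound 1 sits right beside it, and the two cannot be told apart. For the measured compounds named here, compound 3 is the furthest away, with a much higher number; it differs from the others in more than one place and no single step to it is drawn.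

The change to be followed is 1,3-benzothiazol-2-yl in place of 4-methylphenyl on a carbonyl carbon, giving compound 4, `CC(C)[C@@H](NC(=O)c1nc2ccccc2s1)C(=O)N1CCC(c2ccc(Cl)cc2)CC1`. Going by the values given here, the only measured step that bears on it is the exchange of the acyl group on the same carbonyl carbon, a 1.0-fold lower number from compound 1 to compound 2 (0.02 log units; within the scatter). That step swapped an alkyl chain for an aromatic ring without moving the number, so the acyl position has so far taken two rather different groups with no visible effect. Compound 4 keeps the chlorophenyl piperidine and the valine-derived core of compound 2 and only exchanges the acyl aryl group.

Among the compounds with values here, on that basis no shift beyond the scatter is expected; a modest movement in either direction cannot be excluded, since only one comparison exists. Compound 4 is expected to give 30 nM in this assay, between 10 nM and 100 nM, which means an expected step of a 1.2-fold higher number from compound 2 to compound 4 (0.08 log units; within the scatter).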

Compound 4, half-maximal inhibitory concentration: 18 nM
For compound 4 the middle estimate is 1.7-fold (0.22 log units) above the measured one, within the range that was stated.
By their numbers in this assay, from the lowest: compounds 4, 2 and 1 (each within the scatter of the next); then compound 3.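

In this assay, the carbonyl carbon now carries a third type of group: 1,3-benzothiazol-2-yl brings the ring hetero atoms and hydrogen-bond acceptors that 4-methylphenyl lacks, yet the number does not separate (a 1.4-fold lower number from compound 2 to compound 4 (0.14 log units; within the scatter)). The comparison with the alkyl chain reads the same (a 1.4-fold lower number from compound 1 to compound 4 (0.16 log units; within the scatter)), so isopentyl, 4-methylphenyl and 1,3-benzothiazol-2-yl cannot be told apart on the shared core, and the earlier finding from a single pair now holds across three groups of quite different make-up. No measured evidence is available on why this position shows so little response to these exchanges.

From the compounds shown here alone, it remains open whether an acyl group carrying an amine or a carboxylic acid would also leave the number in place, since all three groups compared here have no net charge. Compound 3 differs from compounds 1, 2 and 4 in more than one place, so its steps to them cannot be read, and the separate contributions of its fluorine on the phenyl ring and its unsubstituted benzoyl group remain unresolved.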